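This account rests on a few compounds, and the source may have more. Where it says the series, first, only, none or still open, it means among the compounds named here.

Compound 2 `COc1ccc2c(c1)NC(=O)CN2c1nc(OCC2CC2)nc2ccccc12` gives 15.8 nM in a functional assay on A549 cells (Homo sapiens) for inhibition, read by sulforhodamine B assay, with a stated time of 48 h (a higher number here means a weaker inhibitor of growth, a lower number a stronger inhibitor of growth), the highest of the three numbers measured. Compound 1 `COc1ccc2c(c1)NC(=O)CN2c1nc(COC(C)=O)nc2ccccc12` gives 5.52 nM, and compound 3 `COc1ccc2c(c1)NC(=O)CN2c1nc(NCc2ccncc2)nc2ccccc12` gives 6.62 nM; the step of a 2.9-fold higher number from compound 1 to compound 2 (0.46 log units; beyond the scatter) and the step of a 2.4-fold lower number from compound 2 to compound 3 (0.38 log units; beyond the scatter) both lie beyond the scatter, while a 1.2-fold higher number from compound 1 to compound 3 (0.08 log units; within the scatter) does not. Compound 4 `COc1ccc2c(c1)NC(=O)CN2c1nc(N2CC(OC)C2)nc2ccccc12` carries the change 3-methoxyazetidin-1-yl in place of cyclopropylmethoxy on an aromatic carbon at the carbon between two ring nitrogen atoms. The step from compound 2 to compound 3 bears most directly on this, since it also swaps cyclopropylmethoxy for a nitrogen-linked group and lowers the number modestly. A similar modest lowering is therefore expected, giving a 2.0-fold lower number from compound 2 to compound 4 (0.30 log units; within the scatter). Compound 4 is estimated at 8 nM, with a range from 3 nM to 22 nM.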

Compound 4, concentration for 50% growth inhibition: 17.5 nM
Compound 4: middle estimate off by 2.2-fold (0.34 log units), on the low side, within the range that was stated.
By their numbers in this assay, from the lowest: compounds 1 and 3 (each within the scatter of the next); then compounds 2 and 4 (each within the scatter of the next).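

A nitrogen link at the carbon between two ring nitrogen atoms does not by itself lower the number in this assay: the 3-methoxyazetidin-1-yl group matches the oxygen-linked cyclopropylmethoxy (a 1.1-fold higher number from compound 2 to compound 4 (0.04 log units; within the scatter)). Two nitrogen-linked groups can also differ, as the ((pyridin-4-yl)methyl)amino group shows (a 2.6-fold higher number from compound 3 to compound 4 (0.42 log units; beyond the scatter)), and acetoxymethyl, which has a carbon link, gives a similar separation (a 3.2-fold higher number from compound 1 to compound 4 (0.50 log units; beyond the scatter)). Nothing available explains these differences. Still open, on these data alone, is how a simple azetidine without the methoxy group, a morpholine ring or a longer chain ending in an amine would read at this carbon.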